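The source may hold more compounds than are shown below. What is called first, only, known or untested is meant among the compounds shown, and "the series" means these compounds.

Working notes on the series. Compound 1 `COc1ccc(/C=C2\CCC/C(=C\c3cccc([N+](=O)[O-])c3)C2=O)cc1` gives 10.4 ug/mL in a functional assay on SK-N-MC cells (Homo sapiens) for cytotoxicity, read by MTT assay; on this read-out higher numbers stand for weaker inhibition and lower numbers for stronger inhibition. Compound 2 `CCOc1c(Br)cc(/C=C2\CCC/C(=C\c3cccc([N+](=O)[O-])c3)C2=O)cc1OC` gives 10.8 ug/mL in this assay; the two numbers lie within the scatter of each other, so compound 1 stands level with compound 2 on the numbers shown. Compound 3 `O=C1/C(=C/c2cccc(Cl)c2)CCC/C1=C\c1cccc([N+](=O)[O-])c1` carries 3-chlorophenyl in place of 4-methoxyphenyl on a double-bonded chain carbon bound to a double-bonded ring carbon. For the measured compounds named here, no measured step of this kind is available, so nothing beyond the scatter is expected. The step of a 1.0-fold higher number from compound 1 to compound 3 (0.00 log units; within the scatter) is estimated to be small, and compound 3 is expected to give 10.5 ug/mL in this assay, with a range from 5 ug/mL to 22 ug/mL.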

Compound 3, half-maximal inhibitory concentration: 4.15 ug/mL
Compound 3: the middle estimate sits 2.5-fold (0.40 log units) above what was measured; measured number outside the range, below it.
By their numbers in this assay, from the lowest: compound 3; then compounds 1 and 2 (each within the scatter of the next).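

In this assay, the place on a double-bonded chain carbon bound to a double-bonded ring carbon proves sensitive to the aryl group: 3-chlorophenyl in place of 4-methoxyphenyl gives a 2.5-fold lower number from compound 1 to compound 3 (0.40 log units; beyond the scatter). No measured evidence accompanies this step, and its origin stays unassigned.

As far as these compounds go, the step swaps both the substituent and its ring position, so the share of each stays open; 4-chlorophenyl and 3-methoxyphenyl would separate them. From the compounds shown here alone, how an amine or a carboxylic acid on this phenyl would read also remains open.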